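Changing the Amide Ring on a Shared Core

The compounds below may be only part of what the source reports. "The series", "measured", "known", "first", "only" and "open" are said of these compounds alone.

In an in vivo ADME assay on the whole organism (strain CD-1) for pharmacokinetics, with Mus musculus as the target, at a dose of 10 mg/kg by the oral route (a higher number here means more compound in the circulation at the dose given, a lower number less compound in the circulation), compound 2 (`COc1cc(N2CCC(CC(=O)N3CCN(C)CC3)CC2)ccc1Nc1nc(NC2CCCCC2)c2nc[nH]c2n1`) gives 300 nM, the lower of the two numbers available. Compound 1 (`COc1cc(N2CCC(CC(=O)N3CCOCC3)CC2)ccc1Nc1nc(NC2CCCCC2)c2nc[nH]c2n1`) gives 1400 nM. Compound 3 (`COc1cc(N2CCC(CC(=O)N3CCCC3)CC2)ccc1Nc1nc(NC2CCCCC2)c2nc[nH]c2n1`) keeps the shared core and changes one group on a carbonyl carbon, with pyrrolidin-1-yl in place of 4-methylpiperazin-1-yl on a carbonyl carbon. Among the measured compounds shown here, the one measured step that bears on this is a 4.7-fold lower number from compound 1 to compound 2 (0.67 log units; beyond the scatter), modest but beyond the scatter, with 4-methylpiperazin-1-yl in place of morpholin-4-yl at that same place. Pyrrolidin-1-yl itself has not been measured, so this step is only a rough guide. Losing 4-methylpiperazin-1-yl might recover part of the gap to compound 1, which gives 1400 nM. A rise somewhat smaller than the measured step is therefore expected, estimated as a 3.0-fold higher number from compound 2 to compound 3 (0.48 log units; beyond the scatter). For compound 3 the estimated value is 900 nM, with an expected range from 300 nM to 2700 nM.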

Compound 3, maximal plasma concentration: 1800 nM
Estimate against measurement, compound 3: 2.0-fold (0.30 log units) below; low and high end bracket the measured number.
By their numbers in this assay, from the lowest: compound 2; then compounds 1 and 3 (each within the scatter of the next).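

In this assay, pyrrolidin-1-yl in place of 4-methylpiperazin-1-yl on the carbonyl carbon gives a 6.0-fold higher number from compound 2 to compound 3 (0.78 log units; beyond the scatter), so the low number of compound 2 does not carry over to this new ring. Pyrrolidin-1-yl in place of morpholin-4-yl gives a 1.3-fold higher number from compound 1 to compound 3 (0.11 log units; within the scatter), which lies within the scatter, so a five-membered ring and a six-membered ring cannot be told apart here, and ring size alone does not set compound 2 apart from compounds 1 and 3. Nothing available explains why compound 2 stands apart. 

On these data alone, it remains open whether an unsubstituted piperazin-1-yl, a piperidin-1-yl or an open-chain dimethylamino group on the same carbonyl carbon would side with compound 2 or with compounds 1 and 3. These three compounds also leave open whether the same picture would hold with the amide replaced by a carboxylic acid.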